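The source may report more compounds than this note shows. Statements on the series, on what has been measured and on what is new or still open speak of the compounds shown alone.

Compound 1 `O=C(/C=C/c1ccc(O)cc1)c1c(O)cccc1OCCC1CCCC1` gives 18000 nM in an assay on THP-1 cells for inhibition of nuclear factor NF-kappa-B complex (Homo sapiens), with stated times of 2 h and 16 h; on this read-out lower numbers stand for stronger inhibition and higher numbers for weaker inhibition. Compound 2 `CC(C)(C)CCOc1cccc(O)c1C(=O)/C=C/c1ccc(O)cc1` gives 3000 nM. Compound 3 `CC(C)COc1cccc(O)c1C(=O)/C=C/c1ccc(O)cc1` gives 8000 nM.

Among these three numbers compound 3 stands second highest: it is nearer to compound 1, a 2.3-fold lower number from compound 1 to compound 3 (0.35 log units; beyond the scatter), and further from compound 2, a 2.7-fold higher number from compound 2 to compound 3 (0.43 log units; beyond the scatter). Compound 4 `CCCCOc1cccc(O)c1C(=O)/C=C/c1ccc(O)cc1` differs from compound 3 only in the chain on the ether oxygen: propyl in place of isopropyl on a saturated chain carbon bound to an oxygen on an aromatic ring. Every measured step also changed this chain, and each of them was modest, including a 6.0-fold lower number from compound 1 to compound 2 (0.78 log units; beyond the scatter). None swapped a branched chain for a straight one of the same size, so the direction of this step is not shown. Compound 4 is therefore expected to sit close to compound 3, with a step of a 1.1-fold lower number from compound 3 to compound 4 (0.06 log units; within the scatter) that stays within the scatter, giving an estimated 7000 nM (range 3000 nM to 17000 nM).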

Compound 4, half-maximal inhibitory concentration: > 30000 nM
Compound 4 gave a limit, no number; the forecaster's own chance of this, stated with the estimate: 5%; middle value at least 4.2-fold (0.63 log units) away from the limit.
By their numbers in this assay, from the lowest: compound 2; then compound 3; then compound 1. At a limit, above all of these: compound 4.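

Putting propyl in place of isopropyl on a saturated chain carbon bound to an oxygen on an aromatic ring keeps the same carbons, yet gives an at least 3.7-fold higher number from compound 3 to compound 4 (0.57 log units; beyond the scatter). Among these compounds, the straight chain also falls behind the chain ending in tert-butyl, with an at least 10-fold higher number from compound 2 to compound 4 (1.00 log units; beyond the scatter), so the shape of this chain matters as well as its size, which no earlier step could show. Compound 4 stands only as a limit: the limit of > 30000 nM in this assay, at which 1 of the 4 values shown sits.

The comparison with the cyclopentyl chain cannot be ordered, with an at least 1.6-fold higher number from compound 1 to compound 4 (0.22 log units; that floor lies within the scatter). As far as these compounds go, whether a longer straight chain, or an amine at the chain end, would fare any better remains open.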